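The compounds below may be only part of what the source reports. "The series", "measured", "known", "first", "only" and "open" are said of these compounds alone.

Compound 1 `CN(C)C(=O)c1cc(-c2cnc(NCc3c(F)ccc4c3CCO4)c3cn[nH]c(=O)c23)n(C)n1` gives 3000 nM in a physicochemical assay for solubility, read by LC-MS, in phosphate buffer, with a stated time of 24 h, at pH 7.4 (on this read-out higher numbers stand for higher solubility and lower numbers for lower solubility), the lowest of the two numbers recorded; the nearest is compound 3 `CN(C(=O)c1ccccc1)c1cnc(NCc2c(F)ccc3c2CCO3)n2cnnc12`, which gives 280000 nM. Compound 2 `CN(c1ccccc1)c1cnc(NCc2c(F)ccc3c2CCO3)n2cnnc12` gives only a limit of this assay, < 2000 nM (the limit of < 2000 nM in this assay, at which 1 of the 3 values shown sits). Going by the values given here, the single measured step, an at least 140-fold higher number from compound 2 to compound 3 (2.14 log units; beyond the scatter), is large. Compound 4 `Cc1ncccc1-c1cnc(NCc2c(F)ccc3c2CCO3)c2cn[nH]c(=O)c12` differs from compound 1 by 2-methylpyridin-3-yl in place of 3-(dimethylcarbamoyl)-1-methyl-1H-pyrazol-5-yl on an aromatic carbon. Among the compounds with values here, no measured step involves this change or this position, so the only step on record does not bear on it, and the size of the expected step is uncertain. The step from compound 1 to compound 4 is expected to be modest, a 1.5-fold lower number from compound 1 to compound 4 (0.18 log units; within the scatter). Compound 4 is expected to give about 2000 nM, with a range from 500 nM to 8000 nM.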

Compound 4, solubility: < 2000 nM
Compound 4 was reported as a limit; the forecaster's own chance of this, stated with the estimate: 30%; the middle value lies on the limit itself.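

In this assay compound 4 gives only a limit, < 2000 nM. The change to 2-methylpyridin-3-yl on this aromatic carbon gives an at least 1.5-fold lower number from compound 1 to compound 4 (0.17 log units; that floor lies within the scatter), the first step read at this position, so its true size remains unfixed and it may or may not exceed the usual scatter. Compound 4 joins compound 2 at the floor of the read-out: the limit of < 2000 nM in this assay, at which 2 of the 4 values shown sit.

The compounds shown leave open whether a group carrying an amine or a carboxylic acid on this aromatic carbon would give a number clear of that limit, and so a step of readable size from compound 1.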